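A few compounds are considered here, and "the series" means these few. Any claim that something is new, unique, unknown or untested is made for them only; others in the source may bear on it.

Values so far in a functional assay (trachea) with Cavia porcellus as the target; on this read-out higher numbers stand for an effect only at larger amounts of compound and lower numbers for an effect already at smaller amounts
- compound 1 `CCCn1c(=O)n(CCC(=O)O)c(=O)c2[nH]cnc21` gives 21200 nM
- compound 2 `CCCn1c(=O)n(CCN(C)C)c(=O)c2[nH]cnc21` gives 2700 nM

Compound 2 stands at the lower of the two numbers (2700 nM) and is the reference point for the next comparison. Still unmeasured, compound 3 `CCCn1c(=O)n(CCO)c(=O)c2[nH]cnc21` carries the change hydroxy in place of dimethylamino on a saturated chain carbon, two bonds along the chain from an aromatic nitrogen and so has hydroxy in place of dimethylamino on a saturated chain carbon, two bonds along the chain from an aromatic nitrogen.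

Within the data shown here, only one measured step bears on this change. The step of a 7.9-fold lower number from compound 1 to compound 2 (0.89 log units; beyond the scatter) is modest and brought dimethylamino to the same place in exchange for carboxy. Among the measured compounds shown here, compound 3 also lacks dimethylamino, but no measured compound carries hydroxy, so that step guides the direction and gives only a rough scale. A modest rise in the number is expected, smaller than the measured step. The expected change in this assay is a 2.4-fold higher number from compound 2 to compound 3 (0.38 log units; beyond the scatter) and this remains uncertain. Compound 3 is therefore estimated at 6500 nM (expected range 2500 nM to 17000 nM).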

Compound 3, half-maximal effective concentration: 510 nM
Beside the measured number, compound 3's estimate is 13-fold (1.11 log units) above it; measured number below the stated range.
By their numbers in this assay, from the lowest: compound 3; then compound 2; then compound 1.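

Hydroxy in place of dimethylamino on a saturated chain carbon, two bonds along the chain from an aromatic nitrogen, gives a 5.3-fold lower number from compound 2 to compound 3 (0.72 log units; beyond the scatter) in this assay and so reverses the direction suggested by the earlier pair, while hydroxy in place of carboxy gives a 42-fold lower number from compound 1 to compound 3 (1.62 log units; beyond the scatter) on the same read-out. Dimethylamino therefore no longer holds the lowest number at this position, and the order from the lowest is now hydroxy, dimethylamino, carboxy, with every step between the three compounds beyond the scatter. Among these compounds, the span reached by changing this one group is also wider than the single earlier step showed, but no measurement at hand accounts for this order.

The compounds shown leave open whether the low number depends on the free hydroxy itself or on the 2-hydroxyethyl chain as a whole, which a methyl ether, a primary amine or a longer chain ending in hydroxy at this position would help to separate. Going by these compounds, all three compounds also share the rest of the core, so it remains open whether the same order would hold with a different group elsewhere on it.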